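The compounds below may be only part of what the source reports. "The series", "measured", "known", "first", "only" and "open" are said of these compounds alone.

Two compounds of this series have a value in an ADME assay on NIH3T3 cells (Mus musculus) for cytotoxicity, read by MTT assay, with a stated time of 24 h; on this read-out lower numbers stand for stronger inhibition and higher numbers for weaker inhibition. Compound 1 `Cc1nnc(SCC(=O)N/N=c2/scc(-c3ccc([N+](=O)[O-])cc3)n2-c2ccccc2)s1` gives 177 ug/mL, and compound 2 `Cn1nnnc1SCC(=O)N/N=c1/scc(-c2ccc(C#N)cc2)n1-c1ccccc1` gives 213 ug/mL, the higher of the two numbers, though its gap to compound 1 lies within the usual scatter. Compound 3 `Cc1nnc(SCC(=O)N/N=c2/scc(-c3ccc(C#N)cc3)n2-c2ccccc2)s1` is still unmeasured; it differs from compound 2 by 5-methyl-1,3,4-thiadiazol-2-yl in place of 1-methyl-1H-tetrazol-5-yl on a sulfur. Compound 1 carries the same 5-methyl-1,3,4-thiadiazol-2-yl group and gives 177 ug/mL, close to compound 2, so no step beyond the scatter is expected in this assay. Compound 3 is expected to give 190 ug/mL, within 120 ug/mL to 300 ug/mL. This means an expected step of a 1.1-fold lower number from compound 2 to compound 3 (0.05 log units; within the scatter).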

Compound 3, half-maximal inhibitory concentration: < 3.9 ug/mL
Compound 3: no number, only a limit; the forecaster's own chance of this, stated with the estimate: 10%; middle value at least 48-fold (1.68 log units) away from the limit.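

The sulfur group alone does not set the level in this assay: 5-methyl-1,3,4-thiadiazol-2-yl in place of 1-methyl-1H-tetrazol-5-yl on a sulfur gives an at least 54-fold lower number from compound 2 to compound 3 (1.73 log units; beyond the scatter), while cyano in place of nitro on an aromatic carbon gives an at least 45-fold lower number from compound 1 to compound 3 (1.65 log units; beyond the scatter). The large change thus appears only when 5-methyl-1,3,4-thiadiazol-2-yl and cyano occur together, which compound 1 and compound 2 could not show. Both steps end at a limit, not a number: the limit of < 3.9 ug/mL in this assay, at which 1 of the 3 values shown sits.

The compounds shown leave open how nitro reads with 1-methyl-1H-tetrazol-5-yl on the sulfur. On these data alone, how an amine in place of cyano on the aromatic carbon would read also stays open.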